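A Methoxy Swap on a Weak Growth Inhibitor

The source may hold more compounds than are shown below. What is called first, only, known or untested is meant among the compounds shown, and "the series" means these compounds.

In a functional assay on U-251 cells (Homo sapiens) for inhibition, read by sulforhodamine B assay, with a stated time of 48 h (a higher number here means a weaker inhibitor of growth, a lower number a stronger inhibitor of growth), compound 1 `CCOC(=O)c1nn(-c2ccccc2)c(-c2ccc(Cl)cc2)c1CNC(C)(C)C` gives 73800 nM; > 559000 nM (2 entries). Compound 2 `CC(C)(C)NCc1c(C(=O)O)nn(-c2ccccc2)c1-c1ccc(Cl)cc1` has no number in this assay, only the limit > 652000 nM. Compound 3 `COc1ccc(-c2c(CNC(C)(C)C)c(C(=O)O)nn2-c2ccccc2)cc1` differs from compound 2 at a single place: methoxy in place of chloro on an aromatic carbon. This is methoxy in place of chloro on an aromatic carbon, para to a large group, so that 4-chlorophenyl becomes 4-methoxyphenyl. Among the measured compounds shown here, no measured pair shows what this change does. The expectation in this assay is therefore no shift beyond the scatter, in either direction. The estimated step is an at least 1.1-fold lower number from compound 2 to compound 3 (0.07 log units; that floor lies within the scatter). Compound 3 is expected at about 550000 nM, with an estimated range of 150000 nM to 800000 nM, and the assay may well report only a limit.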

Compound 3, concentration for 50% growth inhibition: > 659000 nM
Compound 3 was reported as a limit; the forecaster's own chance of this, stated with the estimate: 75%; middle value at least 1.1-fold (0.07 log units) away from the limit.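

In this assay compound 2 is reported only as the limit > 652000 nM. Compound 3 is also reported only as a limit, > 659000 nM. Among the compounds shown here, no step between compound 2 and compound 3 can be read from these two limits. The compounds shown leave open whether methoxy in place of chloro changes growth inhibition at all.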